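This account rests on a few compounds, and the source may have more. Where it says the series, first, only, none or still open, it means among the compounds named here.

Measured in a functional assay on A549 cells (Homo sapiens) for cytotoxicity; on this read-out lower numbers stand for stronger inhibition and higher numbers for weaker inhibition:
Compound 1 `C=C/C=C\[C@H](C)[C@H](OC(N)=O)[C@@H](C)[C@H](O)[C@@H](C)C/C(C)=C\[C@H](C)[C@@H](O)[C@@H](C)/C=C\CCc1ccc(Oc2ccccc2)cc1`: 10000 nM
Compound 2 `C=C/C=C\[C@H](C)[C@H](OC(N)=O)[C@@H](C)[C@H](O)[C@@H](C)C/C(C)=C\[C@H](C)[C@@H](O)[C@@H](C)/C=C\CCc1ccc(C)c(F)c1`: 4000 nM

These two compounds share a core and differ in the aromatic group at the end of the chain. On this assay, compound 2 at 4000 nM holds the lower of the two numbers, and its gap to compound 1 at 10000 nM lies beyond the usual scatter. Compound 3 `C=C/C=C\[C@H](C)[C@H](OC(N)=O)[C@@H](C)[C@H](O)[C@@H](C)C/C(C)=C\[C@H](C)[C@@H](O)[C@@H](C)/C=C\CCc1cccc(F)c1` has not yet been measured. It departs from compound 2 by a single change: hydrogen in place of methyl on an aromatic carbon. This puts hydrogen in place of methyl on an aromatic carbon, ortho to a fluoro group and para to a large group, so that 3-fluoro-4-methylphenyl becomes 3-fluorophenyl. Among the measured compounds shown here, no measured pair isolates this change, so the size of the step in this assay can only be judged loosely. A small move towards a higher number is expected, one that stays within the scatter. The estimated change is a 1.5-fold higher number from compound 2 to compound 3 (0.18 log units; within the scatter). For compound 3 the expected value is 6000 nM, with an estimated range of 2500 nM to 15000 nM.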

Compound 3, half-maximal inhibitory concentration: 650 nM
Estimate against measurement, compound 3: 9.2-fold (0.97 log units) above, outside the stated range (below it).
By their numbers in this assay, from the lowest: compound 3; then compound 2; then compound 1.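

In this assay, among the compounds shown here, taking the methyl off the 3-fluoro-4-methylphenyl group to leave 3-fluorophenyl gives a 6.2-fold lower number from compound 2 to compound 3 (0.79 log units; beyond the scatter) and this step lies beyond the scatter, making it the first change that can be read on its own. It shows that this aromatic carbon, ortho to a fluoro group and para to a large group, is not a silent position: the loss of a single carbon atom there moves the read-out clearly, and the move runs towards stronger inhibition. Nothing measured here accounts for the size or direction of this step.

Going by these compounds, whether the step belongs to the loss of the methyl alone or depends on the fluoro group remaining on the ring stays open, and a plain phenyl group at the end of the chain would speak to that. Also open, on these data alone, is how this carbon would respond to a substituent other than hydrogen or methyl, such as a chlorine atom, a methoxy group or an amine.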